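Swapping the Group on Sulfur: Compound 3 to Compound 4

This account rests on a few compounds, and the source may have more. Where it says the series, first, only, none or still open, it means among the compounds named here.

- Compound 1 `COc1ccc(CN(C(=O)Cn2cc(COc3ccccc3)nn2)c2cc(OC)c(OC)c(OC)c2)cc1`: 20500 nM
- Compound 2 `COc1ccc(CN(C(=O)Cn2cc(CSc3nc4ccccc4s3)nn2)c2cc(OC)c(OC)c(OC)c2)cc1`: 49200 nM
- Compound 3 `COc1ccc(CN(C(=O)Cn2cc(CSc3nc4ccccc4o3)nn2)c2cc(OC)c(OC)c(OC)c2)cc1`: 15600 nM

In a functional assay on HepG2 cells (Homo sapiens) for antiproliferative activity, read by MTT assay, with a stated time of 48 h (a higher number here means a weaker inhibitor, a lower number a stronger inhibitor), two compounds share the low end, with a 1.3-fold lower number from compound 1 to compound 3 (0.12 log units; within the scatter), and the third lies apart, with a 3.2-fold lower number from compound 2 to compound 3 (0.50 log units; beyond the scatter). Compound 4 `COc1ccc(CN(C(=O)Cn2cc(CSc3nncs3)nn2)c2cc(OC)c(OC)c(OC)c2)cc1`, not yet measured, carries a new group on the sulfur: 1,3,4-thiadiazol-2-yl in place of 1,3-benzoxazol-2-yl on a sulfur. Going by the values given here, the closest precedent is the swap on that same sulfur between the two fused groups, which was modest. Replacing phenoxy gave a 2.4-fold higher number from compound 1 to compound 2 (0.38 log units; beyond the scatter), also modest. Among the compounds with values here, no tested compound carries 1,3,4-thiadiazol-2-yl, so the direction remains uncertain. In this assay, the expected result is a 1.6-fold higher number from compound 3 to compound 4 (0.20 log units; within the scatter). For compound 4 the estimated value is 25000 nM, with an expected range of 8000 nM to 70000 nM.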

Compound 4, half-maximal inhibitory concentration: 38600 nM
For compound 4 the middle estimate is 1.5-fold (0.19 log units) below the measured one, within the range that was stated.
By their numbers in this assay, from the lowest: compounds 3, 1, 4 and 2 (each within the scatter of the next, the first and the last beyond it).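

With a 2.5-fold higher number from compound 3 to compound 4 (0.39 log units; beyond the scatter) in this assay the 1,3,4-thiadiazol-2-yl group, which has no six-membered aromatic ring, does not match 1,3-benzoxazol-2-yl on this sulfur. Yet a 1.3-fold lower number from compound 2 to compound 4 (0.11 log units; within the scatter) and a 1.9-fold higher number from compound 1 to compound 4 (0.27 log units; within the scatter) leave it not separable from 1,3-benzothiazol-2-yl or from phenoxy. Nothing measured here gives a reason for these steps. Still open, from the compounds shown here alone, is how an amine or a plain alkyl chain in place of the aromatic group on this sulfur would read.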